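A Second Methyl on Compound 2

This account rests on a few compounds, and the source may have more. Where it says the series, first, only, none or still open, it means among the compounds named here.

In a functional assay on SK-OV-3 cells (Homo sapiens) for cytotoxicity (on this read-out lower numbers stand for stronger inhibition and higher numbers for weaker inhibition), compound 1 (`Cc1ccc(-c2cc3ccccc3c(O)n2)cc1`) gives 13800 nM, and compound 2 (`Cc1ccc2c(O)nc(-c3ccccc3)cc2c1`) gives 1700 nM. Compound 2 therefore holds the lower of the two numbers, and the gap between them lies beyond the scatter. Compound 3 (`Cc1ccc(-c2cc3cc(C)ccc3c(O)n2)cc1`) departs from compound 2 by a single change, methyl in place of hydrogen on an aromatic carbon, para to a large group. Among the compounds with values here, no measured pair shows this change alone, so the evidence for its effect is thin. Within the data shown here, the only hint comes from compound 1, which also carries a methyl at that place and gives 13800 nM. A small move towards a higher number in this assay, perhaps no larger than the scatter, is expected, a 1.8-fold higher number from compound 2 to compound 3 (0.25 log units; within the scatter). For compound 3 the estimated value is 3000 nM, with an expected range of 900 nM to 10000 nM.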

Compound 3, half-maximal inhibitory concentration: 4900 nM
Beside the measured number, compound 3's estimate is 1.6-fold (0.21 log units) below it, and the stated range covers the measured number.
By their numbers in this assay, from the lowest: compound 2; then compound 3; then compound 1.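

Methyl in place of hydrogen on an aromatic carbon, para to a large group, now has a measured step of its own in this assay: it gives a 2.9-fold higher number from compound 2 to compound 3 (0.46 log units; beyond the scatter) and so moves the number towards weaker inhibition. The same exchange at the other methyl-bearing place runs the opposite way, giving a 2.8-fold lower number from compound 1 to compound 3 (0.45 log units; beyond the scatter) and moving the number towards stronger inhibition, so its direction depends on where on the core it is made. The data at hand offer no explanation for either step.

As far as these compounds go, whether a chlorine atom, a methoxy group or an amine at the place para to a large group would give a lower or a higher number remains open. So does the number for the core with neither methyl, which would show how each methyl acts without the other.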